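Aryl swap from compound 3 to compound 4

The source may report more compounds than this note shows. Statements on the series, on what has been measured and on what is new or still open speak of the compounds shown alone.

In a functional assay on HT-29 cells (Homo sapiens) for antiproliferative activity, read by sulforhodamine B assay, with a stated time of 48 h (on this read-out higher numbers stand for weaker inhibition and lower numbers for stronger inhibition), compound 1 `CN1CCN(c2ccc(S(=O)(=O)Oc3cccc(F)c3)cc2)C1=O` gives > 100000 nM, which is a limit and not a number. Compound 2 `CCCN1CCN(c2ccc(S(=O)(=O)Oc3cccc(F)c3)cc2)C1=O` gives 18000 nM. The chain change shows an at least 5.5-fold lower number from compound 1 to compound 2 (0.74 log units; beyond the scatter). Compound 3 `CCCCN1CCN(c2ccc(S(=O)(=O)Oc3ccccc3OC)cc2)C1=O` gives > 100000 nM, also a limit, and stands at the limit of > 100000 nM in this assay, at which 2 of the 3 values shown sit.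

Compound 4 `CCCCN1CCN(c2ccc(S(=O)(=O)Oc3cccc(F)c3)cc2)C1=O` follows from 3-fluorophenyl in place of 2-methoxyphenyl on an oxygen, with 3-fluorophenyl in place of 2-methoxyphenyl on an oxygen. It keeps the butyl chain of compound 3 and carries the 3-fluorophenyl of compound 2. For the measured compounds named here, no measured step isolates this swap, so the chain step above is the only guide. With compound 2 at 18000 nM as the nearest number, a move to a lower number is expected in this assay. The expected size is an at least 8.3-fold lower number from compound 3 to compound 4 (0.92 log units; beyond the scatter). Compound 4 is estimated at 12000 nM, within a range of 3000 nM to 50000 nM.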

Compound 4, half-maximal inhibitory concentration: 76000 nM
Beside the measured number, compound 4's estimate is 6.3-fold (0.80 log units) below it; measured number outside the range, above it.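

In this assay, with 3-fluorophenyl on the oxygen, going from the propyl to the butyl chain reverses the earlier gain in a modest step, giving a 4.2-fold higher number from compound 2 to compound 4 (0.63 log units; beyond the scatter). Of the three 3-fluorophenyl compounds, compound 2 is therefore the most active, and the chain does not improve steadily with length. Two further steps start from a limit and give only a floor, not a size: an at least 1.3-fold lower number from compound 3 to compound 4 (0.11 log units; that floor lies within the scatter) and an at least 1.3-fold lower number from compound 1 to compound 4 (0.11 log units; that floor lies within the scatter). Compound 1 and compound 3 each stand at a limit and not at a number: the limit of > 100000 nM in this assay, at which 2 of the 4 values shown sit.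

From the compounds shown here alone, the effect of the aryl swap alone remains open, as does whether the propyl chain would also give a measurable number with 2-methoxyphenyl. A pentyl chain or a chain ending in an amine would test how far this chain trend extends.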